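Swapping the benzyl group of a weakly cytotoxic amide

The source may report more compounds than this note shows. Statements on the series, on what has been measured and on what is new or still open speak of the compounds shown alone.

Measured compounds:
Compound 1 `COC(=O)c1nc(Br)c2cccnc2c1N[C@H]1CC[C@H](N)CC1`: "not determined" (no result reported)
Compound 2 `N[C@H]1CC[C@H](Nc2c(C(=O)NCc3cccc(C(F)(F)F)c3)nc(Br)c3cccnc23)CC1`: "not determined" (no result reported)
Compound 3 `N[C@H]1CC[C@H](Nc2c(C(=O)NCc3ccc(Cl)cc3Cl)nc(Br)c3cccnc23)CC1`: 6000 nM

Three compounds share a core. In a functional assay on SK-BR-3 cells (Homo sapiens) for cytotoxicity, read by MTT assay, with a stated time of 72 h (on this read-out higher numbers stand for weaker inhibition and lower numbers for stronger inhibition), compound 1 gives "not determined" (no result reported) and compound 2 gives "not determined" (no result reported). In this assay compound 3 gives 6000 nM. Among the compounds with values here, that single number is the whole footing here: with one measured point there is no measured step to compare against, so compound 3 stands alone rather than high or low among peers.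

Compound 4 `COc1ccc(CNC(=O)c2nc(Br)c3cccnc3c2N[C@H]2CC[C@H](N)CC2)cc1` differs from compound 3 in one place: 4-methoxyphenyl in place of 2,4-dichlorophenyl on a saturated chain carbon bound to an amide-type nitrogen. Nothing measured speaks to what this swap does, so the expectation rests on the bare fact that compound 3 is already weak and that an exchange of one aryl group for another, with one acceptor added, usually moves such a read-out only modestly.

The step from compound 3 to compound 4 is expected to be small, in the direction of slightly weaker inhibition, a 1.7-fold higher number from compound 3 to compound 4 (0.22 log units; within the scatter), and may not exceed the scatter. Compound 4 is estimated at 10000 nM, within 3000 nM to 30000 nM.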

Compound 4, half-maximal inhibitory concentration: 5000 nM
Beside the measured number, compound 4's estimate is 2.0-fold (0.30 log units) above it; the range from low to high includes it.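

In this assay, within the data shown here, putting 4-methoxyphenyl in place of 2,4-dichlorophenyl on a saturated chain carbon bound to an amide-type nitrogen gives a 1.2-fold lower number from compound 3 to compound 4 (0.08 log units; within the scatter) and so provides the first measured step at this position. The two compounds cannot be told apart on this read-out, so removing both chlorine atoms and adding a methoxy group makes no visible difference in this one pair, which sets no general rule. Nothing available explains why the two aryl groups give such similar results.

Steps involving compound 1 and compound 2 cannot be read, as neither has a reported result. From the compounds shown here alone, it remains open whether a carboxylic acid, a primary amine or a longer chain carrying the aryl ring at this position would move the number beyond the scatter.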